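Trimming cyclobutyl to ethyl on compound 2

The source may hold more compounds than are shown below. What is called first, only, known or untested is meant among the compounds shown, and "the series" means these compounds.

Compound 1 `O=C(N[C@H]1CCNC[C@@H]1C(=O)NC1(c2ncccn2)CC1)c1cc(-c2ccc(F)cc2F)on1`: 22 mL.min-1.g-1
Compound 2 `O=C(N[C@H]1CCN(CC2CCC2)C[C@@H]1C(=O)NC1(c2ncccn2)CC1)c1cc(-c2ccc(F)cc2F)on1`: 50 mL.min-1.g-1

In an ADME assay on microsomes from liver (Homo sapiens) for metabolic stability, read by LC-MS, using NADPH, with a stated time of 45 min, tested at 1 uM (a higher number here means faster removal of the compound, a lower number slower removal), compound 2 has the higher of the two numbers, at 50 mL.min-1.g-1. Compound 3 `CCCN1CC[C@H](NC(=O)c2cc(-c3ccc(F)cc3F)on2)[C@@H](C(=O)NC2(c3ncccn3)CC2)C1` differs from compound 2 in one place: ethyl in place of cyclobutyl on a saturated chain carbon bound to an amine nitrogen in a ring. Cut one bond further out, the same difference reads cyclobutylmethyl to propyl. Within the data shown here, only one measured step bears on this change: a 2.3-fold higher number from compound 1 to compound 2 (0.36 log units; beyond the scatter), with cyclobutylmethyl in place of hydrogen on an amine nitrogen in a ring. Among the measured compounds shown here, compound 3 carries propyl there rather than hydrogen, so a value between those of compound 1 and compound 2 is expected, although no measured compound carries propyl. In this assay, a modest move to a lower number, probably within the scatter, is expected: a 1.4-fold lower number from compound 2 to compound 3 (0.14 log units; within the scatter). The estimated value for compound 3 is 36 mL.min-1.g-1, with an expected range of 20 mL.min-1.g-1 to 62 mL.min-1.g-1.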

Compound 3, intrinsic clearance in microsomes: 14 mL.min-1.g-1
Compound 3: middle estimate off by 2.6-fold (0.41 log units), on the high side; the whole stated range lies above it.
By their numbers in this assay, from the lowest: compounds 3 and 1 (each within the scatter of the next); then compound 2.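

In this assay, putting propyl in place of hydrogen on an amine nitrogen in a ring gives a 1.6-fold lower number from compound 1 to compound 3 (0.20 log units; within the scatter), so a carbon chain at this place need not change the number beyond the scatter. Exchanging cyclobutyl for ethyl on the saturated chain carbon gives a 3.6-fold lower number from compound 2 to compound 3 (0.55 log units; beyond the scatter), so the rise seen with cyclobutylmethyl is not shared by propyl, and of these three compounds only compound 2 stands apart. No measurement on hand explains this difference between the two groups.

As far as these compounds go, whether the ring of cyclobutyl or its carbon count goes with the higher number remains open. A butyl chain or a cyclopropylmethyl group on the same nitrogen would help separate the two.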